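The source may hold more compounds than are shown below. What is called first, only, known or untested is meant among the compounds shown, and "the series" means these compounds.

Among the measured compounds shown here, the three compounds measured so far share one core and differ only in the group on the amide-type nitrogen. Compound 1 `COCOc1cc(/C=C/C(=O)OCC(=O)Nc2ccc(OC)cc2)ccc1OCc1ccccc1` carries a 4-methoxyphenyl there; in a functional assay on HL-60 cells (Homo sapiens) for cytotoxicity, read by MTT assay, with a stated time of 72 h (a higher number here means a weaker inhibitor, a lower number a stronger inhibitor), compound 1 gives > 200000 nM, which is a limit of the assay and not a number. Compound 2 `COCOc1cc(/C=C/C(=O)OCC(=O)Nc2ccc(Cl)cc2)ccc1OCc1ccccc1` carries a 4-chlorophenyl instead, and in this assay compound 2 gives > 200000 nM, again only a limit. Compound 3 `COCOc1cc(/C=C/C(=O)OCC(=O)Nc2nccs2)ccc1OCc1ccccc1` carries a 1,3-thiazol-2-yl, and in this assay compound 3 gives > 200000 nM, also a limit. Compound 3 thus stands where the other two stand: all three sit at the limit (the limit of > 200000 nM in this assay, at which 3 of the 3 values shown sit), and the steps a step that the two limits leave unreadable from compound 1 to compound 2, a step that the two limits leave unreadable from compound 1 to compound 3 and a step that the two limits leave unreadable from compound 2 to compound 3 cannot be read in size or direction.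

Compound 4 `COCOc1cc(/C=C/C(=O)OCC(=O)NCc2ccco2)ccc1OCc1ccccc1` is not yet measured. It differs from compound 3 in one place: (furan-2-yl)methyl in place of 1,3-thiazol-2-yl on an amide-type nitrogen. All three measured steps bear on this change, since each swaps the group on the same nitrogen, yet none yields a readable size. There is therefore no basis for expecting a step beyond the scatter in either direction, and compound 4 is expected most likely to sit at the limit as well. For compound 4 the estimate in this assay is 300000 nM, in the range 100000 nM to 1000000 nM. This corresponds to an expected step that the limit leaves unreadable from compound 3 to compound 4.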

Compound 4, half-maximal inhibitory concentration: 82200 nM
Beside the measured number, compound 4's estimate is 3.6-fold (0.56 log units) above it; measured number below the stated range.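

In this assay, among the compounds shown here, the group on the amide-type nitrogen now has a readable effect for the first time: (furan-2-yl)methyl gives an at least 2.4-fold lower number from compound 3 to compound 4 (0.38 log units; beyond the scatter), and the same change gives an at least 2.4-fold lower number from compound 2 to compound 4 (0.38 log units; beyond the scatter) and an at least 2.4-fold lower number from compound 1 to compound 4 (0.38 log units; beyond the scatter). For the compounds shown here, this shows that a change at this one position can bring the result off the limit, something the earlier steps could not show, as none of them could be read in size or direction. The new steps give only a minimum size, and the true size of each remains unknown, as the other compounds all stay at the limit: the limit of > 200000 nM in this assay, at which 3 of the 4 values shown sit.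

The change from the 1,3-thiazol-2-yl group alters the ring and also places a methyl link between ring and nitrogen, and the compounds shown do not tell which of these two differences matters, a question that a benzyl or a (1,3-thiazol-2-yl)methyl group on this nitrogen would address. Also open, as far as these compounds go, is how the number would respond to a longer chain, such as 2-(furan-2-yl)ethyl, in place of the (furan-2-yl)methyl group.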